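Methoxycarbonyl to benzyloxycarbonyl on the shared core

A few compounds are considered here, and "the series" means these few. Any claim that something is new, unique, unknown or untested is made for them only; others in the source may bear on it.

Measured in a functional assay on A549 cells (Homo sapiens) for cytotoxicity, read by MTT assay; a lower number here means a stronger inhibitor, a higher number a weaker inhibitor:
compound 1 `C=C1C(=O)[C@]23C[C@@]1(Cl)CC[C@H]2[C@@]12C=CC(=O)[C@](C)(C(=O)O1)[C@H]2[C@@H]3C(=O)OCc1ccccc1`: 28800 nM
compound 2 `C=C1C(=O)[C@]23C[C@@]1(F)CC[C@H]2[C@@]12C=CC(=O)[C@](C)(C(=O)O1)[C@H]2[C@@H]3C(=O)OCc1ccccc1`: 64400 nM
compound 3 `C=C1C(=O)[C@]23C[C@@]1(OC)CC[C@H]2[C@@]12C=CC(=O)[C@](C)(C(=O)O1)[C@H]2[C@@H]3C(=O)OC`: 54500 nM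

Compound 3, at 54500 nM, lies within the usual scatter of both compound 1 and compound 2, even though those two are separated by a step beyond the scatter. The next compound is compound 4 `C=C1C(=O)[C@]23C[C@@]1(OC)CC[C@H]2[C@@]12C=CC(=O)[C@](C)(C(=O)O1)[C@H]2[C@@H]3C(=O)OCc1ccccc1`, which differs from compound 3 by phenyl in place of hydrogen on a saturated chain carbon bound to an oxygen next to a carbonyl group. This is phenyl in place of hydrogen on a saturated chain carbon bound to an oxygen next to a carbonyl group, so that methoxycarbonyl becomes benzyloxycarbonyl.

For the measured compounds named here, no measured pair isolates this change. Going by the values given here, the only measured step is a 2.2-fold higher number from compound 1 to compound 2 (0.35 log units; beyond the scatter), a modest one that puts fluoro in place of chloro on a saturated ring carbon, and it does not touch the ester. Indirect support comes from the two compounds that already carry benzyloxycarbonyl: compound 1 gives 28800 nM and compound 2 gives 64400 nM, both close to compound 3. No step beyond the scatter is therefore expected in this assay. The expected change is a 1.2-fold lower number from compound 3 to compound 4 (0.08 log units; within the scatter). The estimate for compound 4 is 45000 nM, with an expected range from 22000 nM to 90000 nM.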

Compound 4, half-maximal inhibitory concentration: 28200 nM
Beside the measured number, compound 4's estimate is 1.6-fold (0.20 log units) above it; measured number inside the range.
By their numbers in this assay, from the lowest: compounds 4, 1, 3 and 2 (each within the scatter of the next, the first and the last beyond it).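

In this assay, for the compounds shown here, the change from methoxycarbonyl to benzyloxycarbonyl, read directly for the first time with methoxy held on the saturated ring carbon, gives a 1.9-fold lower number from compound 3 to compound 4 (0.29 log units; within the scatter), so the phenyl on this saturated chain carbon does not separate the two esters. With benzyloxycarbonyl held, compound 4 also adds two readings at the saturated ring carbon: methoxy in place of fluoro gives a 2.3-fold lower number from compound 2 to compound 4 (0.36 log units; beyond the scatter), a modest step beyond the scatter, whereas methoxy in place of chloro gives a 1.0-fold lower number from compound 1 to compound 4 (0.01 log units; within the scatter), which leaves compound 1 and compound 4 indistinguishable. No evidence is available to explain either the flat result at the ester or the separation of compound 2 from compound 4.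

Going by these compounds, the methoxycarbonyl ester appears here only with methoxy on the saturated ring carbon, so it remains open whether the same change would read alike with chloro or fluoro there. Also open, on these data alone, is whether a carboxylic acid, an amide or a longer chain in place of the benzyl group would produce a step beyond the scatter.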